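Pyrazolyl urea series: ring nitrogen substituent and thermal shift

A few compounds are considered here, and "the series" means these few. Any claim that something is new, unique, unknown or untested is made for them only; others in the source may bear on it.

Going by the values given here, compound 2 `Cc1ccc(-n2nc(C(C)(C)C)cc2NC(=O)Nc2cc(F)cc(F)c2)cc1` gives 0.6 degrees C in an assay on isolated protein for inhibition of serine/threonine-protein kinase 10 (Homo sapiens), read by thermal shift assay, tested at 10 uM (on this read-out higher numbers stand for stronger stabilisation of the target against heat and lower numbers for weaker stabilisation of the target), the lowest of the two numbers so far; nearest is compound 1 `CC(C)(C)c1cc(NC(=O)Nc2cc(F)cc(F)c2)n(-c2ccccc2)n1`, which gives 2.5 degrees C. The single measured step, a number 1.9 degrees C lower from compound 1 to compound 2 (beyond the scatter), concerns a methyl on an aromatic carbon only. Compound 3 `Cn1nc(C(C)(C)C)cc1NC(=O)Nc1cc(F)cc(F)c1` differs from compound 2 by methyl in place of 4-methylphenyl on an aromatic nitrogen. Among the compounds with values here, no measured step covers removing the aromatic ring from the ring nitrogen, so the direction is open; compound 2 is expected to move by a number 0.60 degrees C higher from compound 2 to compound 3 (within the scatter), a step within the scatter. Compound 3 is therefore expected to give 1.2 degrees C, between -0.3 degrees C and 2.7 degrees C.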

Compound 3, shift of the target's melting temperature: 1.1 degrees C
Estimate against measurement, compound 3: 0.10 degrees C above; the measured number falls inside the stated range.
By their numbers in this assay, from the lowest: compounds 2 and 3 (each within the scatter of the next); then compound 1.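

Going by these compounds alone, on the aromatic nitrogen, methyl in place of 4-methylphenyl gives no step that can be read in this assay (a number 0.50 degrees C higher from compound 2 to compound 3 (within the scatter)), so compound 2 and compound 3 stand level. Methyl in place of phenyl does give a step beyond the scatter (a number 1.4 degrees C lower from compound 1 to compound 3 (beyond the scatter)), so of these three compounds only compound 1, with the unsubstituted phenyl, stands apart, and the aromatic ring alone does not set it apart from compound 2.

As far as these compounds go, whether an amine or a carboxylic acid on the phenyl, or a longer chain on the aromatic nitrogen, would hold or change the shift stays open. No available evidence accounts for these differences.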